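The source may report more compounds than this note shows. Statements on the series, on what has been measured and on what is new or still open speak of the compounds shown alone.

The series shares one core, to which a group hangs from a saturated chain carbon bound to an aromatic nitrogen. Compound 1 `COc1ccc(Cn2c(=O)n(C3OC(CO)[C@@H](O)[C@H]3O)c3nc(N)nc(O)c32)cc1` carries a 4-methoxyphenyl there; in a functional assay (B cells) with Mus musculus as the target (a higher number here means that more compound is needed for the effect, a lower number that less compound is needed), compound 1 gives 135 uM. Compound 2 `Nc1nc(O)c2c(n1)n(C1OC(CO)[C@@H](O)[C@H]1O)c(=O)n2Cc1ccc(Cl)cc1` carries a 4-chlorophenyl and in this assay compound 2 gives 14 uM, a change of a 9.6-fold lower number from compound 1 to compound 2 (0.98 log units; beyond the scatter). Compound 3 `N#Cc1cccc(Cn2c(=O)n(C3OC(CO)[C@@H](O)[C@H]3O)c3nc(N)nc(O)c32)c1` carries a 3-cyanophenyl and in this assay compound 3 gives 3 uM, the lowest number of the three, with a 45-fold lower number from compound 1 to compound 3 (1.65 log units; beyond the scatter) and a 4.7-fold lower number from compound 2 to compound 3 (0.67 log units; beyond the scatter).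

Compound 4 `Cn1c(=O)n(C2OC(CO)[C@@H](O)[C@H]2O)c2nc(N)nc(O)c21` removes the ring altogether: hydrogen in place of 3-cyanophenyl on a saturated chain carbon bound to an aromatic nitrogen. Among the measured compounds shown here, the steps that bear on it are those that swapped one aryl for another at this carbon, a 45-fold lower number from compound 1 to compound 3 (1.65 log units; beyond the scatter) and a 4.7-fold lower number from compound 2 to compound 3 (0.67 log units; beyond the scatter), both moving the number downward when the 3-cyanophenyl arrived. For the measured compounds named here, removing that group entirely goes further than any measured step; no measured compound lacks the ring. A large rise in the number is therefore expected, a 33-fold higher number from compound 3 to compound 4 (1.52 log units; beyond the scatter). Compound 4 is estimated at 100 uM, within 20 uM to 500 uM.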

Compound 4, concentration for half-maximal effect: 10 uM
Compound 4: middle estimate off by 10-fold (1.00 log units), on the high side; measured number outside the range, below it.
By their numbers in this assay, from the lowest: compound 3; then compounds 4 and 2 (each within the scatter of the next); then compound 1.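

Hydrogen in place of 3-cyanophenyl at this carbon, the change from 3-cyanobenzyl to methyl, costs only a modest step in this assay, a 3.3-fold higher number from compound 3 to compound 4 (0.52 log units; beyond the scatter), so the aromatic ring is not required for activity in the low range seen here. The ring's contribution depends on what it carries: 4-chlorophenyl and hydrogen cannot be told apart, with a 1.4-fold lower number from compound 2 to compound 4 (0.15 log units; within the scatter), while 4-methoxyphenyl stands on the unfavourable side of hydrogen, with a 14-fold lower number from compound 1 to compound 4 (1.13 log units; beyond the scatter), leaving 3-cyanophenyl as the only one of the three aryl groups that clearly gives a lower number than hydrogen. No evidence is available to explain these differences.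

The compounds shown leave open how an unsubstituted phenyl would compare with hydrogen at this carbon. They also leave open what a longer chain, such as propyl, or a chain ending in an amine would do in place of the methyl.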